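Cytotoxicity notes: tetrazolyl versus triazolyl thioether on the hydrazone

The compounds below may be only part of what the source reports. "The series", "measured", "known", "first", "only" and "open" are said of these compounds alone.

Measured compounds and values
- compound 1, `Cc1ccc(-c2cs/c(=N/NC(=O)CSc3nnnn3-c3ccccc3)n2-c2ccccc2)cc1`, 29.5%
- compound 2, `O=C(CSc1nnnn1-c1ccccc1)N/N=c1/scc(-c2ccc(Cl)cc2)n1-c1ccccc1`, 60%
- compound 3, `Cn1cnnc1SCC(=O)N/N=c1/scc(-c2ccc(C#N)cc2)n1-c1ccccc1`, 58.8%

In a functional assay on C6 cells (Rattus norvegicus) for cytotoxicity, read by MTT assay, with a stated time of 24 h, tested at 50 ug/mL (on this read-out higher numbers stand for a weaker effect at the one concentration tested and lower numbers for a stronger effect), compound 3 stands second highest of the three numbers; its value and that of compound 2 lie within the scatter of each other, while compound 1 lies beyond the scatter below it. Within the data shown here, the one measured step, a number 30.5 percentage points higher from compound 1 to compound 2 (beyond the scatter), concerns the substituent on the aryl ring and not the thioether.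

Compound 4, `N#Cc1ccc(-c2cs/c(=N/NC(=O)CSc3nnnn3-c3ccccc3)n2-c2ccccc2)cc1`, differs from compound 3 by 1-phenyl-1H-tetrazol-5-yl in place of 4-methyl-4H-1,2,4-triazol-3-yl on a sulfur. Among the measured compounds shown here, no measured step carries this change, so no step beyond the scatter is expected in this assay; the value of compound 4 is estimated at 58%, range 40% to 76%, a step of a number 0.8 percentage points lower from compound 3 to compound 4 (within the scatter).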

Compound 4, a percentage reported as activity, at one concentration (the size of the read-out at that concentration, not a potency): 61.1%
The estimate for compound 4 lay 3.1 percentage points below the measured number; measured number inside the range.
By their numbers in this assay, from the lowest: compound 1; then compounds 3, 2 and 4 (each within the scatter of the next).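

In this assay, 1-phenyl-1H-tetrazol-5-yl in place of 4-methyl-4H-1,2,4-triazol-3-yl on a sulfur gives no change beyond the scatter with cyano kept on the aromatic carbon (a number 2.3 percentage points higher from compound 3 to compound 4 (within the scatter)). With the tetrazolyl group held, cyano and chloro are not separated (a number 1.1 percentage points higher from compound 2 to compound 4 (within the scatter)), whereas cyano and methyl are (a number 31.6 percentage points higher from compound 1 to compound 4 (beyond the scatter)), so among these compounds only the methyl compound stands apart.

Still open, going by these compounds, is what an amine or a carboxylic acid on that sulfur would give, and whether the same exchange is as silent with methyl on the aromatic carbon. No measurement at hand accounts for these results.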